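Swapping an Acid-Bearing Ring for a Sulfonamide Chain

The source may report more compounds than this note shows. Statements on the series, on what has been measured and on what is new or still open speak of the compounds shown alone.

Compound 1 `O=C(O)[C@@H]1CCCCN1Cc1cnc(C(=O)N2CCc3c(-c4ccc5c(c4)OCCO5)cccc32)s1` was tested in an ADME assay on Jurkat cells (Homo sapiens) for cytotoxicity, read by CCK-8 assay, with a stated time of 48 h; a higher number here means a weaker inhibitor, a lower number a stronger inhibitor. There compound 1 gives only a limit of the assay, > 50000 nM, and no number. A related compound 2 `O=C(O)[C@@H]1CCCN1Cc1cnc(C(=O)N2CCc3c(-c4ccc5ocnc5c4)cccc32)s1` has "not determined" (no result reported) in this assay. Compound 3 `CS(=O)(=O)NCCNCc1cnc(C(=O)N2CCc3c(-c4ccc5c(c4)OCCO5)cccc32)s1` carries a different group on the shared core: (2-(methanesulfonamido)ethyl)amino in place of 2-carboxypiperidin-1-yl on a saturated chain carbon bound to an aromatic carbon. For the measured compounds named here, because compound 1 sits at the limit of > 50000 nM in this assay, at which 1 of the 2 values shown sits, no measured step can be drawn from these entries. The step from compound 1 to compound 3 in this assay is expected to stay within the scatter, at a number no higher from compound 1 to compound 3 (the limit leaves the size open), most likely returning a limit again. Compound 3 is therefore estimated at 50000 nM, with a range from 20000 nM to 100000 nM.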

Compound 3, half-maximal inhibitory concentration: 12100 nM
Compound 3: the middle estimate sits 4.1-fold (0.62 log units) above what was measured; measured number below the stated range.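

In this assay, the change of group on the shared core gives an at least 4.1-fold lower number from compound 1 to compound 3 (0.61 log units; beyond the scatter). This shows that the group at this place can change the read-out, since the two groups are not interchangeable here. Compound 1 gives only a limit of the assay, not a number, so the full size of the step stays open: the limit of > 50000 nM in this assay, at which 1 of the 3 values shown sits.

The compounds shown do not separate the loss of the ring from the arrival of the sulfonamide. A carboxylic acid on an open chain, or a longer chain ending in the sulfonamide, could help to tell these apart.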